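This account rests on a few compounds, and the source may have more. Where it says the series, first, only, none or still open, it means among the compounds named here.

In a functional assay on NCI-H460 cells (Homo sapiens) for positive allosteric modulation, read by MTT assay, with stated times of 2 h and 72 h, tested at 1 uM (a lower number here means a stronger inhibitor, a higher number a weaker inhibitor), compound 1 (`CCCc1ccc(C(=O)Nc2ccccc2-c2nnn(-c3cccc(OC)c3)n2)cc1`) gives 207 nM. Compound 2 (`COc1cccc(-n2nnc(-c3ccccc3NC(=O)c3ccc(N=[N+]=[N-])cc3)n2)c1`) gives 558 nM, the higher of the two numbers, which makes it the weaker inhibitor of this pair. Going by the values given here, only one measured step connects them: a 2.7-fold higher number from compound 1 to compound 2 (0.43 log units; beyond the scatter), with azido in place of propyl on an aromatic carbon. Compound 3 (`COc1cccc(-n2nnc(-c3ccccc3NC(=O)Nc3ccc([N+](=O)[O-])cc3)n2)c1`) has (4-nitrophenyl)amino in place of 4-azidophenyl on a carbonyl carbon. This is a different kind of change, so the modest step of a 2.7-fold higher number from compound 1 to compound 2 (0.43 log units; beyond the scatter) offers only a rough guide to size and none to direction. Among the compounds with values here, no measured pair here tests this replacement, so no shift beyond the scatter is predicted in this assay. The expected change is a 1.1-fold lower number from compound 2 to compound 3 (0.05 log units; within the scatter). For compound 3, the estimated value is 500 nM, with a likely range of 150 nM to 1700 nM.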

Compound 3, half-maximal inhibitory concentration: 179 nM
The estimate for compound 3 lay 2.8-fold (0.45 log units) above the measured number; measured number inside the range.
By their numbers in this assay, from the lowest: compounds 3 and 1 (each within the scatter of the next); then compound 2.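

Swapping 4-azidophenyl for (4-nitrophenyl)amino on the carbonyl carbon gives a 3.1-fold lower number from compound 2 to compound 3 (0.49 log units; beyond the scatter) in this assay, so the group at this position can shift the number in the stronger direction as well as the weaker one. Replacing 4-propylphenyl with the same group gives a 1.2-fold lower number from compound 1 to compound 3 (0.06 log units; within the scatter), so these two groups are not told apart here, even though the entering group adds an amide-type nitrogen and a hydrogen-bond donor. Nothing available explains either step.

Compound 3 differs from compound 2 in both its nitro group and the added nitrogen on the carbonyl carbon, so the compounds shown cannot say which of these two features accounts for the step. They also leave open how a carboxylic acid or an amine in place of the nitro group would read in this assay.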